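Replacing the 4-hydroxyphenyl group of compound 2 with furan-2-yl

This account rests on a few compounds, and the source may have more. Where it says the series, first, only, none or still open, it means among the compounds named here.

In a functional assay on A549 cells (Homo sapiens) for cytotoxicity (on this read-out higher numbers stand for an effect only at larger amounts of compound and lower numbers for an effect already at smaller amounts), three compounds on a shared core have been measured so far. Compound 1 `COC1=C(C)C(=O)/C(=C(O)/C=C/c2ccc(Br)cc2)C(=O)C1(C)C` gives the lowest number at 1.4 ug/mL and compound 3 `COC1=C(C)C(=O)/C(=C(O)/C=C/c2c(C)cc(C)cc2C)C(=O)C1(C)C` the highest at 8 ug/mL of the three. Compound 2 `COC1=C(C)C(=O)/C(=C(O)/C=C/c2ccc(O)cc2)C(=O)C1(C)C` stands second highest at 3.1 ug/mL and lies nearest to compound 1.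

Compound 4 `COC1=C(C)C(=O)/C(=C(O)/C=C/c2ccco2)C(=O)C1(C)C` has not yet been measured. It differs from compound 2 in one place: furan-2-yl in place of 4-hydroxyphenyl on a double-bonded chain carbon bound to a double-bonded chain carbon while the rest of the core stays the same.

Among the compounds with values here, no measured step exchanges the aromatic ring itself, so the evidence is indirect. Within the data shown here, the only step available is a 2.2-fold higher number from compound 1 to compound 2 (0.35 log units; beyond the scatter) which was modest and changes only a group on that ring. The three measured values also stay fairly close together. A small change is therefore expected, with no firm direction, and the estimate is a 1.3-fold higher number from compound 2 to compound 4 (0.11 log units; within the scatter) for this replacement. In this assay the estimate for compound 4 is 4 ug/mL with an expected range of 1.5 ug/mL to 10 ug/mL as the likely span.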

Compound 4, concentration for half-maximal effect: 10 ug/mL
Estimate against measurement, compound 4: 2.5-fold (0.40 log units) below; the range from low to high includes it.
By their numbers in this assay, from the lowest: compound 1; then compound 2; then compounds 3 and 4 (each within the scatter of the next).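

In this assay the aromatic ring itself proves open to exchange on the double-bonded chain carbon, and the number responds beyond the scatter: furan-2-yl in place of 4-hydroxyphenyl gives the step (a 3.2-fold higher number from compound 2 to compound 4 (0.51 log units; beyond the scatter)), and furan-2-yl in place of 4-bromophenyl gives the larger step (a 7.1-fold higher number from compound 1 to compound 4 (0.85 log units; beyond the scatter)). Both steps run the same way, so among these three compounds the furan-2-yl ring goes with the highest number, and effect is seen at smaller amounts with either substituted phenyl ring. Nothing on hand explains this shift.

The compounds shown leave open whether another five-membered ring, such as thiophen-2-yl, would behave like furan-2-yl. They also leave open how an amine on the phenyl ring, or a plain alkyl chain in place of the ring, would read in this assay.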